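Series notes: methylcarbamoyl in place of propyl

The source may report more compounds than this note shows. Statements on the series, on what has been measured and on what is new or still open speak of the compounds shown alone.

Measured so far:
- compound 1, `CCC[C@@H]1CN[C@H](C(=O)N2CCC[C@H]2C#N)C1`, gives 50% in an assay on the whole organism (plasma, strain Sprague-Dawley) for inhibition of Dipeptidyl peptidase 4 (Rattus norvegicus), with a stated time of 6 h, at a dose of 1 mg/kg by the oral route; on this read-out lower numbers stand for less inhibition and higher numbers for more inhibition at the one dose given (going by the name of the read-out).
- compound 2, `CCN(C)C(=O)[C@@H]1CN[C@H](C(=O)N2CCC[C@H]2C#N)C1`, gives 71% in this assay.

Compound 1 stands lowest of the two numbers; its nearest neighbour is compound 2, reached by the step of a number 21 percentage points higher from compound 1 to compound 2 (beyond the scatter), in which ethyl(methyl)carbamoyl replaces propyl on a saturated ring carbon.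

Compound 3, `CNC(=O)[C@@H]1CN[C@H](C(=O)N2CCC[C@H]2C#N)C1`, is not yet measured. It differs from compound 1 as follows: methylcarbamoyl in place of propyl on a saturated ring carbon. Within the data shown here, the one measured step that bears on this change is a number 21 percentage points higher from compound 1 to compound 2 (beyond the scatter), which was modest and beyond the scatter; it exchanged the same propyl for the larger carbamoyl group at the same place. The same direction is expected for methylcarbamoyl, though a single step gives no firm handle on size. Compound 3 is therefore estimated at 65% in this assay, within the range 45% to 85%. That estimate amounts to the expected step of a number 15 percentage points higher from compound 1 to compound 3 (beyond the scatter), upward and of a size comparable to a number 21 percentage points higher from compound 1 to compound 2 (beyond the scatter).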

Compound 3, a percentage reported as inhibition, in the whole organism at one dose (the size of the read-out at that dose, not a potency): 75%
The estimate for compound 3 lay 10 percentage points below the measured number; low and high end bracket the measured number.
By their numbers in this assay, from the lowest: compound 1; then compounds 2 and 3 (each within the scatter of the next).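

In this assay the step of a number 25 percentage points higher from compound 1 to compound 3 (beyond the scatter) gives a second case beyond the scatter, so the upward move from propyl at this saturated ring carbon, two ring bonds from the ring nitrogen, is not confined to the ethyl(methyl)carbamoyl group. Hydrogen in place of ethyl on the amide-type nitrogen gives a number 4 percentage points higher from compound 2 to compound 3 (within the scatter) and stays within the scatter, so this read-out at one dose does not separate the two carbamoyl groups, and the amide hydrogen present in compound 3 brings no change that can be read here. No available measurement accounts for either step.

The compounds shown leave open how a primary carboxamide, a carboxylic acid or an amine would read at this ring carbon, and therefore whether the carbamoyl groups share their reading with other groups carrying nitrogen or oxygen. Since the read-out is the size of the inhibition at one dose and one stated time, it also leaves open whether compound 2 and compound 3 would stay together at other doses or times.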